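The compounds below may be only part of what the source reports. "The series", "measured", "known", "first", "only" and "open" are said of these compounds alone.

Measured so far in a functional assay on WM 266-4 cells (Homo sapiens) for antiproliferative activity, read by MTT assay, with a stated time of 24 h (on this read-out higher numbers stand for weaker inhibition of growth and lower numbers for stronger inhibition of growth), are three compounds.
- compound 1 `c1ccc(N2N=C(c3ccc4c(c3)OCCO4)CC2c2ccco2)cc1` gives > 100000 nM as a limit of the assay
- compound 2 `FC(F)(F)c1ccc(C2CC(c3ccc4c(c3)OCCO4)=NN2c2ccccc2)cc1` gives > 100000 nM as a limit of the assay
- compound 3 `Fc1ccc(C2CC(c3ccc4c(c3)OCCO4)=NN2c2ccccc2)cc1` gives 6050 nM as a measured number

Among the compounds with values here, compound 3 holds the only number in this small set. The other two values are limits (the limit of > 100000 nM in this assay, at which 2 of the 3 values shown sit).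

Compound 4 `c1ccc(N2N=C(c3ccc4c(c3)OCCO4)CC2c2ccc3ccccc3c2)cc1` carries naphthalen-2-yl in place of 4-fluorophenyl on a saturated ring carbon. Within the data shown here, two measured steps concern the group at this carbon. One is an at least 16-fold lower number from compound 1 to compound 3 (1.21 log units; beyond the scatter) with 4-fluorophenyl in place of furan-2-yl. The other is an at least 16-fold lower number from compound 2 to compound 3 (1.21 log units; beyond the scatter) with fluoro in place of trifluoromethyl on an aromatic carbon. Both are large, and in both the lower number belongs to the 4-fluorophenyl compound. Moving away from 4-fluorophenyl is therefore expected to raise the number in this assay by a moderate to large step, though only three compounds support this. The expected change is a 2.5-fold higher number from compound 3 to compound 4 (0.39 log units; beyond the scatter) on this read-out. For compound 4 the estimate is 15000 nM with an expected range from 2500 nM to 90000 nM in this series.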

Compound 4, concentration for 50% growth inhibition: 13900 nM
Compound 4: middle estimate off by 1.1-fold (0.03 log units), on the high side; measured number inside the range.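

In this assay, a measured number at the saturated ring carbon is not tied to 4-fluorophenyl: naphthalen-2-yl, with its two six-membered aromatic rings of carbon only, gives a 2.3-fold higher number from compound 3 to compound 4 (0.36 log units; beyond the scatter). Naphthalen-2-yl also stands apart from the other two groups at this carbon, with an at least 7.1-fold lower number from compound 2 to compound 4 (0.85 log units; beyond the scatter) and an at least 7.1-fold lower number from compound 1 to compound 4 (0.85 log units; beyond the scatter), so a larger aryl group does not by itself lead to the outcome seen with 4-(trifluoromethyl)phenyl. Both of these comparisons rest on limits of the assay rather than on numbers: the limit of > 100000 nM in this assay, at which 2 of the 4 values shown sit.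

Going by these compounds, whether any group at this carbon gives a lower number than 4-fluorophenyl remains open. Also open, on these data alone, is how a cyclohexyl group, or a phenyl carrying an amine or a carboxylic acid, would behave at this carbon.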